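The compounds below may be only part of what the source reports. "The series", "measured", "known", "first", "only" and "open" are said of these compounds alone.

Of the compounds shown here, two built on one shared core have so far been tested in an ADME assay on cells (Fibroblast, Homo sapiens) for inhibition, read by MTT assay, with a stated time of 24 h; on this read-out lower numbers stand for stronger inhibition and higher numbers for weaker inhibition. Compound 1 `O=C(N/N=C/c1ccc2c(c1)no[n+]2[O-])c1ccc(Cl)c(Cl)c1` gives 65000 nM in this assay. Compound 2 `O=C(N/N=C/c1ccc2c(c1)no[n+]2[O-])c1ccc(Br)cc1` stands at a limit of this assay rather than at a number, reported as > 200000 nM, and that is the limit of > 200000 nM in this assay, at which 1 of the 2 values shown sits. So compound 2 is known only to be weaker than the point the assay can resolve, while compound 1 is placed on the scale.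

The next compound, compound 3 `CCCCOc1ccc(C(=O)N/N=C/c2ccc3c(c2)no[n+]3[O-])cc1`, differs from compound 2 in a single place: butoxy in place of bromo on an aromatic carbon. Going by the values given here, no pair of measured compounds shows what such a swap does on this core, so the direction of the step rests on expectation alone. With compound 2 sitting at a limit, even a modest gain in inhibition could bring compound 3 onto the scale; the expected step is an at least 1.3-fold lower number from compound 2 to compound 3 (0.12 log units; that floor lies within the scatter), a move that may still fall within the ordinary scatter of this assay. On that basis compound 3 is estimated at 150000 nM, with a range from 40000 nM to 400000 nM.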

Compound 3, half-maximal inhibitory concentration: > 200000 nM
Compound 3 ended at the assay's limit (the forecaster's own chance of this, stated with the estimate: 45%); at least 1.3-fold (0.12 log units) between middle value and limit.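

Compound 2 and compound 3 both stand at a limit in this assay rather than at a number, so no step can be read from the swap of bromo for butoxy: the limit of > 200000 nM in this assay, at which 2 of the 3 values shown sit.

The compounds shown leave open how far past that limit each compound lies, and whether this swap changes inhibition at all.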